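The source may report more compounds than this note shows. Statements on the series, on what has been measured and on what is new or still open speak of the compounds shown alone.

Compound 2 `Cc1c(OCCCCOc2ccc(C(=O)O)c(Cl)c2)ccc(C(=O)CC(C)C)c1O` carries the only numerical result in this set: in an assay on HEK293 cells for positive allosteric modulation of metabotropic glutamate receptor 3 (Rattus norvegicus), read by thallium flux, with a stated time of 2.5 min (on this read-out lower numbers stand for an effect already at smaller amounts and higher numbers for an effect only at larger amounts of compound), compound 2 gives 2050 nM. Compound 1 `Cc1ccc(C(=O)O)cc1OCCCCOc1ccc(C(=O)CC(C)C)c(O)c1C` stands at the limit of the assay, as in this assay compound 1 gives > 10000 nM, a limit rather than a number (the limit of > 10000 nM in this assay, at which 1 of the 2 values shown sits). Between the two lies the one measured step, an at least 4.8-fold lower number from compound 1 to compound 2 (0.68 log units; beyond the scatter), which changed the group on the oxygen on the saturated carbon. Compound 3 `Cc1c(OCCCCOc2ccc(F)c(C(=O)O)c2)ccc(C(=O)CC(C)C)c1O` alters that same group: 3-carboxy-4-fluorophenyl in place of 4-carboxy-3-chlorophenyl on an oxygen on a saturated carbon. For the measured compounds named here, since the single measured step on this position was at least modest, and compound 3 moves the carboxy away from the arrangement found in compound 2 toward a pattern of the kind seen in compound 1, a rise in the number, possibly back toward the limit, is expected. Compound 3 is therefore estimated at 5000 nM, with a range of 1500 nM to 20000 nM, meaning an expected step of a 2.4-fold higher number from compound 2 to compound 3 (0.39 log units; beyond the scatter).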

Compound 3, half-maximal effective concentration: 920 nM
Estimate against measurement, compound 3: 5.4-fold (0.74 log units) above; measured number below the stated range.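

Compound 3 shows that this position tolerates more than one arrangement of carboxy and halogen: in this assay, 3-carboxy-4-fluorophenyl in place of 4-carboxy-3-chlorophenyl gives a 2.2-fold lower number from compound 2 to compound 3 (0.35 log units; beyond the scatter), so the gain seen with compound 2 is not tied to the 4-carboxy-3-chlorophenyl group. The same position also spans a wider range than the first step showed, with 3-carboxy-4-fluorophenyl in place of 5-carboxy-2-methylphenyl giving an at least 10-fold lower number from compound 1 to compound 3 (1.03 log units; beyond the scatter). That step has a bound rather than an exact size, as the value of compound 1 is a limit: the limit of > 10000 nM in this assay, at which 1 of the 3 values shown sits.

The carboxy and the halogen both change from compound 2 to compound 3, so the compounds shown cannot divide the gain between them. Going by these compounds, how a plain 3-carboxyphenyl group, or a tetrazole in place of the carboxylic acid, would read at this position remains open.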